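Chloro to Methyl on the Sulfonyl Aryl Ring

The compounds below may be only part of what the source reports. "The series", "measured", "known", "first", "only" and "open" are said of these compounds alone.

Measured so far in a functional assay on the whole organism (strain albino) for inhibition, with Rattus norvegicus as the target, read by paw edema, with stated times of 30 min and 1 h, at a dose of 25 mg/kg by the intraperitoneal route; on this read-out higher numbers stand for more inhibition at the one dose given (going by the name of the read-out) and lower numbers for less inhibition:
compound 1 `CCOC(=O)c1nn(-c2ccccc2)c(-c2ccc(OC)cc2OC)c1-c1ccccc1`: 17.7%
compound 2 `COc1ccc(C2=NN(C(=O)NS(=O)(=O)c3ccc(Cl)cc3)CC2c2ccccc2)c(OC)c1`: 24.2%
compound 3 `COc1ccc(C2=NN(C(=O)NS(=O)(=O)c3ccc(Cl)cc3)CC2C)c(OC)c1`: 12.3%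

Compound 2 holds the highest of the three numbers, but its gap to compound 1 lies within the scatter, so the two cannot be ranked; only compound 3 stands beyond it. Among the measured compounds shown here, the single measured step between neighbours, a number 11.9 percentage points lower from compound 2 to compound 3 (beyond the scatter), concerns a saturated ring carbon and not the sulfonyl aryl ring. Compound 4 `COc1ccc(C2=NN(C(=O)NS(=O)(=O)c3ccc(C)cc3)CC2c2ccccc2)c(OC)c1` differs from compound 2 in one place: methyl in place of chloro on an aromatic carbon. No measured compound varies this ring, so nothing shown bears directly on the change. The step from compound 2 to compound 3 shows that a change at a saturated ring carbon moves this assay beyond the scatter, yet it says nothing about the aromatic carbon concerned here. For the measured compounds named here, with no step to lean on, the change is expected to leave this assay within the scatter of the value of compound 2. Compound 4 is therefore estimated at 21%, with a range from 9% to 33%. That estimate corresponds to an expected step of a number 3.2 percentage points lower from compound 2 to compound 4 (within the scatter), none beyond the scatter.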

Compound 4, a percentage reported as inhibition, in the whole organism at one dose (the size of the read-out at that dose, not a potency): 4.9%
Estimate against measurement, compound 4: 16.1 percentage points above; the whole stated range lies above it.
By their numbers in this assay, from the lowest: compounds 4, 3, 1 and 2 (each within the scatter of the next, the first and the last beyond it).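

Among the compounds shown here, the step on the sulfonyl aryl ring is the first to test this aromatic carbon, and it shows that the position matters in this assay: putting methyl in place of chloro gives a number 19.3 percentage points lower from compound 2 to compound 4 (beyond the scatter). The exchange is a small one, one heavy atom for one heavy atom, with no ring, hydrogen-bond donor, hydrogen-bond acceptor or net charge counted on either group, yet like a number 11.9 percentage points lower from compound 2 to compound 3 (beyond the scatter) it lies beyond the scatter, so the two changed places of the molecule both move this read-out at the one dose given. No evidence at hand bears on what lies behind the step, and a single pair cannot settle whether it would hold elsewhere in the series.

The compounds shown carry only chloro or methyl at this aromatic carbon, so with a plain hydrogen, a fluoro or a methoxy group unseen there, it stays open whether chloro raises the number or methyl lowers it. Going by these compounds, it also stays open whether the same exchange would act alike on compound 3, which has methyl in place of phenyl on the saturated ring carbon.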